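The compounds below may be only part of what the source reports. "The series", "measured", "known", "first", "only" and "open" are said of these compounds alone.

Compound 1 `CCCNc1nc(N)nc2c1ncn2/C=C1/CC1(CO)CO` is assessed in an ADME assay on HFF cells (Homo sapiens) for cytotoxicity, with a stated time of 8 days; a lower number here means that less compound is tolerated, a higher number that more compound is tolerated. In this assay compound 1 gives only a limit, > 300000 nM. Compound 2 `CN(C)c1nc(N)nc2c1ncn2/C=C1/CC1(CO)CO` likewise gives only a limit, > 300000 nM. Compound 3 `Nc1nc(SC2CCCC2)c2ncn(/C=C3/CC3(CO)CO)c2n1` also reaches only a limit, > 300000 nM. All three values sit at the limit of > 300000 nM in this assay, at which 3 of the 3 values shown sit, so the step that the two limits leave unreadable from compound 1 to compound 2 and the step that the two limits leave unreadable from compound 1 to compound 3 remain unreadable in size, as does a step that the two limits leave unreadable from compound 2 to compound 3. Compound 4 `Nc1nc(SCc2ccccc2)c2ncn(/C=C3/CC3(CO)CO)c2n1` differs from compound 1 by benzylsulfanyl in place of propylamino on an aromatic carbon. Among the measured compounds shown here, no measured step bears readably on this change; every comparison ends at a limit. For compound 4 the estimate is therefore 300000 nM, within 100000 nM to 1000000 nM, and the step of a number no higher from compound 1 to compound 4 (the limit leaves the size open) is expected to be none beyond the scatter.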

Compound 4, half-maximal cytotoxic concentration: > 300000 nM
Compound 4: no number, only a limit; the forecaster's own chance of this, stated with the estimate: 80%; the middle value sits exactly at the limit.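

In this assay compound 4 gives only a limit, > 300000 nM. Its steps to compound 1, compound 2 and compound 3 therefore cannot be read: the limit of > 300000 nM in this assay, at which 4 of the 4 values shown sit. The compounds shown leave open at what concentration any of the four becomes cytotoxic, and whether they differ at all.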